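The source may hold more compounds than are shown below. What is called first, only, known or untested is meant among the compounds shown, and "the series" means these compounds.

Measured so far in an assay on CHO-K1 cells for displacement of a labelled ligand from prostaglandin E2 receptor EP1 subtype (Homo sapiens); a lower number here means a stronger inhibitor, a higher number a weaker inhibitor:
compound 1, `Cc1cc(C(=O)NCc2ccncc2)nn1Cc1cc(Cl)ccc1OCc1ccccc1`, 79.4 nM
compound 2, `Cc1cc(NC(=O)C2CCCCC2)nn1Cc1cc(Cl)ccc1OCC(C)C`, 31.6 nM

Compound 1 holds the highest of the two numbers in this assay, and compound 2 stands a lower number beyond the scatter. Compound 3, `Cc1cc(NC(=O)OC(C)(C)C)nn1Cc1cc(Cl)ccc1OCc1ccccc1`, is not yet measured. It differs from compound 1 in one place: (tert-butoxycarbonyl)amino in place of ((pyridin-4-yl)methyl)carbamoyl on an aromatic carbon. For the measured compounds named here, no step between measured compounds covers this change; compound 2 carries an amide nitrogen on the same core atom and gives a lower number, but its other groups differ too. For compound 3 the expected step of a 1.3-fold lower number from compound 1 to compound 3 (0.12 log units; within the scatter) is small, if anything a slight lowering, within the scatter. Compound 3 is estimated at 60 nM, range 15 nM to 250 nM.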

Compound 3, half-maximal inhibitory concentration: 25.1 nM
Compound 3: middle estimate off by 2.4-fold (0.38 log units), on the high side; low and high end bracket the measured number.
By their numbers in this assay, from the lowest: compounds 3 and 2 (each within the scatter of the next); then compound 1.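

In this assay, (tert-butoxycarbonyl)amino in place of ((pyridin-4-yl)methyl)carbamoyl gives a 3.2-fold lower number from compound 1 to compound 3 (0.50 log units; beyond the scatter) with the rest of the core of compound 1 unchanged. This position therefore keeps binding with no ring in its substituent, and with nitrogen rather than a carbonyl carbon on the aromatic carbon. No measurement available here accounts for the step.

The compounds shown do not separate the loss of the pyridine ring from the switch in attachment. A free amine or an acetylamino group at this position would begin to test how much of the tert-butoxycarbonyl group is needed.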